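Urea Aryl Exchange on a Shared Core

A few compounds are considered here, and "the series" means these few. Any claim that something is new, unique, unknown or untested is made for them only; others in the source may bear on it.

Compound 1 `CCNc1cc(-c2ccc(NC(=O)Nc3ccc(C(F)(F)F)cc3)cc2OC)ccn1`: 40.7%
Compound 2 `CCNc1cc(-c2ccc(NC(=O)Nc3cccc(Cl)c3)cc2F)ccn1`: 72.7%

Both were measured in an assay on isolated protein for inhibition of serine/threonine-protein kinase PLK1 (Homo sapiens), read by radiometric assay and 33P incorporation, with a stated time of 40 min, tested at 20 uM, in the presence of a further agent that is not named here; on this read-out lower numbers stand for less inhibition and higher numbers for more inhibition at the one concentration tested (going by the name of the read-out). Compound 2 gives the higher of the two numbers, and compound 1 sits below it by a gap beyond the usual scatter. Among the compounds with values here, no pair differs in one place only, so the gap cannot be split into parts. Compound 3 `CCNc1cc(-c2ccc(NC(=O)Nc3ccc(C(F)(F)F)cc3)cc2F)ccn1` is not yet measured; it differs from compound 2 thus: 4-(trifluoromethyl)phenyl in place of 3-chlorophenyl on an amide-type nitrogen. Within the data shown here, its entering group is the one carried by compound 1, while the rest of its structure matches compound 2. The expected downward step is a number 14.7 percentage points lower from compound 2 to compound 3 (beyond the scatter). Compound 3 is estimated at 58%, within 35% to 80%.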

Compound 3, a percentage reported as inhibition, at one concentration (the size of the read-out at that concentration, not a potency): 55.8%
Compound 3: middle estimate off by 2.2 percentage points, on the high side; the measured number falls inside the stated range.
By their numbers in this assay, from the lowest: compound 1; then compound 3; then compound 2.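

Compound 3 splits the earlier gap in this assay into two single-place changes: 4-(trifluoromethyl)phenyl in place of 3-chlorophenyl on the amide-type nitrogen gives a number 16.9 percentage points lower from compound 2 to compound 3 (beyond the scatter) and fluoro in place of methoxy on the aromatic carbon gives a number 15.1 percentage points higher from compound 1 to compound 3 (beyond the scatter). Each place therefore matters on its own, and each step lies beyond the scatter. Nothing offered here accounts for either step.

Going by these compounds, whether the fluoro for methoxy step would hold with 3-chlorophenyl on the nitrogen remains open. So does the outcome with a morpholine or a carboxylic acid on that aromatic carbon.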